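This account rests on a few compounds, and the source may have more. Where it says the series, first, only, none or still open, it means among the compounds named here.

Measured in a physicochemical assay for solubility; on this read-out higher numbers stand for higher solubility and lower numbers for lower solubility:
Compound 1 `C[C@H](Oc1ccc(S(C)(=O)=O)cc1C(=O)N1Cc2ccc(N3CCCC3)cc2C1)C(F)(F)F`: < 1 ug/mL, a limit of the assay and not a number.
Compound 2 `C[C@H](Oc1ccc(S(C)(=O)=O)cc1C(=O)N1Cc2ccc(N3CCN(C)CC3)cc2C1)C(F)(F)F`: 490 ug/mL.

Within the data shown here, compound 2 at 490 ug/mL holds the only actual number so far. The result for compound 1 is a limit. Compound 3 `C[C@H](Oc1ccc(S(C)(=O)=O)cc1C(=O)N1Cc2ccc(-c3ccncc3)cc2C1)C(F)(F)F` has pyridin-4-yl in place of 4-methylpiperazin-1-yl on an aromatic carbon. Among the measured compounds shown here, that carbon is the one changed in the single measured step, an at least 490-fold higher number from compound 1 to compound 2 (2.69 log units; beyond the scatter), which is large and beyond the scatter. The size of that step is tied to the limit of < 1 ug/mL in this assay, at which 1 of the 2 values shown sits. For the measured compounds named here, no measured compound carries pyridin-4-yl, so this step is only a rough guide. Going by the values given here, compound 2 is the only compound with a number, and the change removes the group that gave an at least 490-fold higher number from compound 1 to compound 2 (2.69 log units; beyond the scatter), so a large fall in this assay is expected. The expected change, estimated from that single step, is a 61-fold lower number from compound 2 to compound 3 (1.79 log units; beyond the scatter). For compound 3 the estimated value is 8 ug/mL, with an expected range of 1 ug/mL to 60 ug/mL.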

Compound 3, solubility: 25 ug/mL
Compound 3: the middle estimate sits 3.1-fold (0.49 log units) below what was measured; measured number inside the range.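

On the aromatic carbon para to a fused ring, this assay now gives three separate levels rather than a single contrast between two groups. Pyridin-4-yl does not match 4-methylpiperazin-1-yl, with a 20-fold lower number from compound 2 to compound 3 (1.29 log units; beyond the scatter), but it also stands clear of pyrrolidin-1-yl, with an at least 25-fold higher number from compound 1 to compound 3 (1.39 log units; beyond the scatter), so replacing 4-methylpiperazin-1-yl need not take the read-out down to the floor seen for pyrrolidin-1-yl. Compound 1 stands at a limit of the assay and not a number, so the full size of the step from it stays unfixed: the limit of < 1 ug/mL in this assay, at which 1 of the 3 values shown sits.

Pyridin-4-yl and 4-methylpiperazin-1-yl differ at once in whether the six-membered ring is aromatic and in their count of nitrogen atoms, so the compounds shown cannot tell which of these differences goes with the step from compound 2 to compound 3. As far as these compounds go, a morpholin-4-yl or phenyl group on the same carbon would help to pull these two features apart, and whether the order of the three groups holds with any other group on the shared core remains open.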